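Amide aryl variation on a shared core: compound 4

This account rests on a few compounds, and the source may have more. Where it says the series, first, only, none or still open, it means among the compounds named here.

Measured so far in a functional assay on MCF7 cells (Homo sapiens) for antiproliferative activity, read by MTT assay, with a stated time of 72 h; on this read-out lower numbers stand for stronger inhibition and higher numbers for weaker inhibition:
compound 1 `CCc1ccc(C(=O)Nc2ccc3nc(N4CCN(CC)CC4)cc(C)c3c2)cc1` gives 3060 nM;
compound 2 `CCN1CCN(c2cc(C)c3cc(NC(=O)c4ccc(Cl)cc4)ccc3n2)CC1` gives 1530 nM;
compound 3 `CCN1CCN(c2cc(C)c3cc(NC(=O)c4cccc(F)c4)ccc3n2)CC1` gives 8920 nM.

Compound 3 stands at the highest number of the three in this assay: the step of a 2.9-fold higher number from compound 1 to compound 3 (0.46 log units; beyond the scatter) and the step of a 5.8-fold higher number from compound 2 to compound 3 (0.77 log units; beyond the scatter) both exceed the usual scatter, so compound 3 is the weakest of the measured set. Between compound 1 and compound 2 the step of a 2.0-fold lower number from compound 1 to compound 2 (0.30 log units; within the scatter) lies within the scatter.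

Compound 4 `CCN1CCN(c2cc(C)c3cc(NC(=O)c4cc(Cl)cc(Cl)c4)ccc3n2)CC1` differs from compound 3 in one place: 3,5-dichlorophenyl in place of 3-fluorophenyl on a carbonyl carbon. For the measured compounds named here, the steps that bear on it are those leading into compound 3, since each swaps the aryl group on the carbonyl carbon: the 3-fluorophenyl compound sits well above both the 4-chlorophenyl and the 4-ethylphenyl compounds. Going by the values given here, no measured step tests a 3,5-dichlorophenyl group, nor a second halogen on the ring, so the size of the return is uncertain. Because compound 2 gives 1530 nM with a chlorophenyl amide, compound 4 is expected to move back toward that region, giving an expected step of a 3.0-fold lower number from compound 3 to compound 4 (0.47 log units; beyond the scatter). The estimate for compound 4 in this assay is 3000 nM, with a range from 1000 nM to 9000 nM.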

Compound 4, half-maximal inhibitory concentration: 6090 nM
The estimate for compound 4 lay 2.0-fold (0.31 log units) below the measured number, within the range that was stated.
By their numbers in this assay, from the lowest: compounds 2, 1, 4 and 3 (each within the scatter of the next, the first and the last beyond it).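

In this assay, the 3,5-dichlorophenyl amide cannot be told apart from the 3-fluorophenyl amide (a 1.5-fold lower number from compound 3 to compound 4 (0.17 log units; within the scatter)) or from the 4-ethylphenyl amide (a 2.0-fold higher number from compound 1 to compound 4 (0.30 log units; within the scatter)), so replacing fluorine with two chlorines on this aryl group gives no readable gain. Chlorine on the ring is therefore not sufficient in itself to give the number seen with the 4-chlorophenyl amide: the two chlorine-bearing amides are separated beyond the scatter (a 4.0-fold higher number from compound 2 to compound 4 (0.60 log units; beyond the scatter)), which makes the arrangement of substituents on the aryl group matter at this carbonyl carbon, at least for this pair. Nothing measured here explains that separation.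

Still open, going by these compounds, is whether the separation follows the number of chlorines or their placement, a question that 3-chlorophenyl and 3,5-difluorophenyl amides would address directly. Also open, on these data alone, is how this position would respond in this assay to a phenyl ring carrying an amine or a carboxylic acid, or to a pyridine ring in place of the phenyl ring on the carbonyl carbon.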